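The compounds below may be only part of what the source reports. "The series", "measured", "known", "first", "only" and "open" are said of these compounds alone.

Measured so far in an ADME assay on BV-2 cells (Mus musculus) for cytotoxicity, with a stated time of 24 h, tested at 10 uM; on this read-out higher numbers stand for a weaker effect at the one concentration tested and lower numbers for a stronger effect:

Compound 1 `COc1cccc(S(=O)(=O)/C=C/c2ccccn2)c1` gives 100%.
Compound 2 `COc1cccc(S(=O)(=O)/C=C/c2ccc(Cl)cn2)c1` gives 100%.
Compound 3 `COc1ccc(S(=O)(=O)/C=C/c2ccccn2)cc1` gives 100%.

Compound 4 `COc1ccc(S(=O)(=O)/C=C/c2ccc(Cl)cn2)cc1` has not yet been measured. The change from compound 1 to compound 2 is chloro in place of hydrogen on an aromatic carbon, and in this assay it made the step of no change at the digits printed from compound 1 to compound 2 (within the scatter). The change from compound 3 to compound 4 is chloro in place of hydrogen on an aromatic carbon; the place described is the same as before, so this is the same change on a different core. Compound 3 and compound 1 share the same atoms joined differently, but the difference between the two cores is not broken down here. Compound 3 sits level with compound 1 and compound 2 at the digits given.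

Because the earlier step of no change at the digits printed from compound 1 to compound 2 (within the scatter) did not move the read-out, and because compound 3 gives 100%, the step from compound 3 to compound 4 is expected to be no change at the digits printed from compound 3 to compound 4 (within the scatter). Compound 4 is therefore estimated at 100%, with a range from 88% to 100%.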

Compound 4, a percentage reported as activity, at one concentration (the size of the read-out at that concentration, not a potency): 100%
For compound 4 middle estimate and measured number coincide at the digits printed; the measured number falls inside the stated range.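

In this assay, chloro in place of hydrogen on an aromatic carbon gives no change at the digits printed from compound 3 to compound 4 (within the scatter), and set beside the earlier case, the change carries over between the two cores: the same change on two cores in this assay, no change at the digits printed (within the scatter) from compound 1 to compound 2 and no change at the digits printed (within the scatter) from compound 3 to compound 4, 0 percentage points apart, within the scatter of two such steps Within these four compounds, then, chloro can be moved from one core to the other without shifting this read-out. This does not show that chloro is without effect in general: all four compounds stand at the same value, so no shift exists that could be carried over, and the comparison rests on just two steps at one concentration, which says nothing about potency or about any other assay.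

The compounds shown leave open whether another group in that same place, such as fluoro, methyl, an amine or a carboxylic acid, would leave the read-out where it stands. They also leave open whether chloro on another carbon of the ring would behave alike, and whether these compounds would still read the same at a higher concentration.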